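Taking the silyl group off compound 3

This account rests on a few compounds, and the source may have more. Where it says the series, first, only, none or still open, it means among the compounds named here.

Compound 1 `COc1ccc(C2=C(c3cc(OC)c(OC)c(OC)c3)C(=O)C(OC(C)=O)C2)cc1OC(C)C`: > 100 ug/mL
Compound 2 `C=CCOc1cc(C2=C(c3cc(OC)c(OC)c(OC)c3)C(=O)C(O)C2)ccc1OC`: > 100 ug/mL
Compound 3 `COc1ccc(C2=C(c3cc(OC)c(OC)c(OC)c3)C(=O)C(O[SiH2]C(C)(C)C)C2)cc1OC(C)C`: 7.5 ug/mL

Going by the values given here, in an ADME assay on KB cells (Homo sapiens) for cytotoxicity, read by MTT assay, with a stated time of 72 h (a lower number here means a stronger inhibitor, a higher number a weaker inhibitor), compound 3 gives 7.5 ug/mL, the only true number so far. The other two results are limits, not numbers: the limit of > 100 ug/mL in this assay, at which 2 of the 3 values shown sit. Compound 4 `COc1ccc(C2=C(c3cc(OC)c(OC)c(OC)c3)C(=O)C(O)C2)cc1OC(C)C` differs from compound 3 by this change: a hydrogen atom in place of a group of 5 heavy atoms (4 carbon, 1 silicon; no ring), on an oxygen on a saturated carbon. One measured step changes the group on this same oxygen, an at least 13-fold lower number from compound 1 to compound 3 (1.12 log units; beyond the scatter), and it is large. Compound 2 also has a hydrogen on that oxygen, though it differs elsewhere, and it sits at the limit. Losing the group is therefore expected to give a weaker result, with a large upward step. The expected change is an 8.0-fold higher number from compound 3 to compound 4 (0.90 log units; beyond the scatter). For compound 4 the estimated value is 60 ug/mL, with an expected range of 18 ug/mL to 100 ug/mL.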

Compound 4, half-maximal inhibitory concentration: > 100 ug/mL
Compound 4 ended at the assay's limit; the forecaster's own chance of this, stated with the estimate: 50%; middle value at least 1.6-fold (0.22 log units) from the limit.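

With the rest of the molecule unchanged, this pair isolates the group on this oxygen, which compound 2 could not do because it also differs elsewhere: an at least 13-fold higher number from compound 3 to compound 4 (1.12 log units; beyond the scatter). The free hydroxyl of compound 4 and the acetyl group of compound 1 both leave the result at a limit, and only the silyl group of compound 3 gives a true number. The steps from compound 1 and compound 2 to compound 4 cannot be read, as both ends of each are limits.

Whether silicon is needed stays open, since a plain carbon chain such as butyl on this oxygen is not among the compounds shown. On these data alone, how an amine in place of this oxygen would compare also remains unknown.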